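The compounds below may be only part of what the source reports. "The series", "measured", "known", "first", "only" and "open" are said of these compounds alone.

Among the compounds with values here, compound 2 `COc1cccc(/C=C/C(=O)Nc2cc(C(=O)c3cc(OC)c(OC)c(OC)c3)cc(OC)c2OC)c1` gives 8700 nM in a functional assay on HT-29 cells (Homo sapiens) for cytotoxicity, read by MTT assay, with a stated time of 72 h (a higher number here means a weaker inhibitor, a lower number a stronger inhibitor), the highest of the three numbers measured so far: compound 1 `COc1ccc(/C=C/C(=O)Nc2cc(C(=O)c3cc(OC)c(OC)c(OC)c3)cc(OC)c2OC)cc1OC` gives 2300 nM and compound 3 `COc1cc(C(=O)c2cc(OC)c(OC)c(OC)c2)cc(NC(=O)/C=C/c2cc(F)c(F)c(F)c2)c1OC` gives 3300 nM, with a 3.8-fold higher number from compound 1 to compound 2 (0.58 log units; beyond the scatter) and a 2.6-fold lower number from compound 2 to compound 3 (0.42 log units; beyond the scatter). Compound 4 `COc1cc(C(=O)c2cc(OC)c(OC)c(OC)c2)cc(N)c1OC` differs from compound 2 by hydrogen in place of (2-(3-methoxyphenyl)ethenyl)carbonyl on a nitrogen on an aromatic ring. Within the data shown here, no measured step tests this change; the two steps seen only swap one aryl group for another on the very chain that is removed here, so they give no guide to the size or direction of the step. The expectation for compound 4 is thus weakly held, leaning toward a higher number, a 1.5-fold lower number from compound 2 to compound 4 (0.16 log units; within the scatter). Compound 4 is estimated at 6000 nM, between 1500 nM and 25000 nM.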

Compound 4, half-maximal inhibitory concentration: 3800 nM
Compound 4: the middle estimate sits 1.6-fold (0.20 log units) above what was measured, and the stated range covers the measured number.
By their numbers in this assay, from the lowest: compounds 1, 3 and 4 (each within the scatter of the next); then compound 2.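

Removing the whole (2-(3-methoxyphenyl)ethenyl)carbonyl chain from the nitrogen gives a 2.3-fold lower number from compound 2 to compound 4 (0.36 log units; beyond the scatter) in this assay, so this chain is not needed for the cytotoxicity seen with compound 2. Compound 4 also stands within the scatter of compound 3, so the 3,4,5-trifluorophenyl chain shows no measurable gain over the free nitrogen. Nothing available explains the direction of this step. Still open, going by these compounds, is how a small acetyl group on this nitrogen, or a saturated chain in place of the double-bonded one, would compare.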